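Fluorine removal on the benzyl ring of an isatin sulfonamide

This account rests on a few compounds, and the source may have more. Where it says the series, first, only, none or still open, it means among the compounds named here.

The shared core, seen unsubstituted in compound 3 `NS(=O)(=O)c1ccc2c(c1)C(=O)C(=O)N2`, is tested in a functional assay on K562 cells (Homo sapiens) for inhibition, read by MTT assay, with a stated time of 72 h; a lower number here means a stronger inhibitor, a higher number a weaker inhibitor. Compound 3 gives only a limit there, > 50000 nM, which marks the edge of the assay and not a number (the limit of > 50000 nM in this assay, at which 1 of the 3 values shown sits). Two benzyl-bearing analogues carry a trifluoromethyl group on the pendant ring. Compound 1 `NS(=O)(=O)c1ccc2c(c1)C(=O)C(=O)N2Cc1ccc(C(F)(F)F)cc1` gives 16000 nM, and compound 2 `NS(=O)(=O)c1ccc2c(c1)C(=O)C(=O)N2Cc1cc(C(F)(F)F)ccc1F` gives 9000 nM. Among the two numbers recorded, compound 2 stands lowest, but compound 1 sits within the usual scatter of it, so the two are not distinguished by this assay.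

Compound 4 `NS(=O)(=O)c1ccc2c(c1)C(=O)C(=O)N2Cc1cccc(C(F)(F)F)c1` remains to be measured. It differs from compound 2 by hydrogen in place of fluoro on an aromatic carbon. With compound 1 and compound 2 lying within scatter of each other despite their different substitution on the benzyl ring, no step beyond the scatter is expected here either; the estimated step from compound 2 to compound 4 is a 1.4-fold higher number from compound 2 to compound 4 (0.16 log units; within the scatter), with any drift more likely toward a higher number than a lower one. Compound 4 is therefore expected to give about 13000 nM in this assay, within a range from 5000 nM to 35000 nM.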

Compound 4, half-maximal inhibitory concentration: 9800 nM
The estimate for compound 4 lay 1.3-fold (0.12 log units) above the measured number; the range from low to high includes it.
By their numbers in this assay, from the lowest: compounds 2, 4 and 1 (each within the scatter of the next). At a limit, above all of these: compound 3.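

In this assay, hydrogen in place of fluoro on this aromatic carbon, ortho to a large group and para to a trifluoromethyl group, gives a 1.1-fold higher number from compound 2 to compound 4 (0.04 log units; within the scatter). The earlier compounds shown here offered no pair that differed in this one place, and this pair shows that the fluoro group can be exchanged for hydrogen here with no change that this assay can resolve, so the fluoro group of compound 2 is not needed to hold its number. Nothing measured in these data bears on why the exchange leaves the number unchanged.

The compounds shown leave open whether a larger or differently built group on this same aromatic carbon, such as a methoxy group or an amine, would move the number beyond the scatter, as fluoro and hydrogen are the only two groups seen there. They also leave open what the trifluoromethyl group contributes, as it is present in every benzyl-bearing compound shown, and a nitrile or a carboxylic acid in its place would put that to the test.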